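The source may report more compounds than this note shows. Statements on the series, on what has been measured and on what is new or still open speak of the compounds shown alone.

Measured so far:
Compound 1 `COC(=O)N1[C@@H]2C=C[C@@](OC)(C(=O)c3c2cc(OC)c(OC)c3OCc2ccc(F)cc2)N1C(=O)OC` — in an ADME assay on KB cells (Homo sapiens) for cytotoxicity (on this read-out higher numbers stand for an effect only at larger amounts of compound and lower numbers for an effect already at smaller amounts), compound 1 gives 56.6 ug/mL.
Compound 2 `COC(=O)N1[C@@H]2C=C[C@@](OC)(C(=O)c3c2cc(OC)c(OC)c3OCc2ccccc2)N1C(=O)OC` — in this assay compound 2 gives only a limit of the assay, > 300 ug/mL.

From the compounds shown here alone, compound 2 thus stands at the top of what this assay can report: its true number is unknown, and only a limit is recorded (the limit of > 300 ug/mL in this assay, at which 1 of the 2 values shown sits). Compound 3 `COC(=O)N1[C@@H]2C=C[C@@](OC)(C(=O)c3c2cc(OC)c(OC)c3OCc2ccccc2F)N1C(=O)OC` differs from compound 2 by fluoro in place of hydrogen on an aromatic carbon. Among the compounds with values here, one measured step bears on this: going an at least 5.3-fold higher number from compound 1 to compound 2 (0.72 log units; beyond the scatter), the loss of a fluoro raised the number, and that step lies beyond the scatter. Read in reverse, it suggests that putting a fluoro back may lower the number, although compound 3 is not simply compound 1, so the size is uncertain. Compound 3 is therefore expected to show a downward step of an at least 2.5-fold lower number from compound 2 to compound 3 (0.39 log units; beyond the scatter). For compound 3 the estimated value is 120 ug/mL, with a range from 30 ug/mL to 300 ug/mL.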

Compound 3, concentration for half-maximal effect: 137 ug/mL
For compound 3 the middle estimate is 1.1-fold (0.06 log units) below the measured one, within the range that was stated.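

A fluoro on the benzyl ring lowers the number at a second place too: in this assay, 2-fluorobenzyl in place of benzyl gives an at least 2.1-fold lower number from compound 2 to compound 3 (0.34 log units; beyond the scatter). The earlier drop is therefore not confined to the 4-fluorophenyl group. The place of the fluoro also counts, since the change from 4-fluorophenyl to 2-fluorophenyl gives a 2.4-fold higher number from compound 1 to compound 3 (0.38 log units; beyond the scatter). The true size of the step from the unsubstituted benzyl group remains unknown because one end of it is a limit: the limit of > 300 ug/mL in this assay, at which 1 of the 3 values shown sits.

From the compounds shown here alone, whether a chloro or a methoxy on the same ring would also lower the number remains open. Going by these compounds, it is equally open how the read-out would respond if the benzyloxy group gave way to an amine or a longer chain.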